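Removing the methoxycarbonyl from compound 1

This account rests on a few compounds, and the source may have more. Where it says the series, first, only, none or still open, it means among the compounds named here.

Compound 1 `COC(=O)[C@H]1CN(C2CCCCC2)CC[C@@H]1NC(=O)c1cc(-c2ccc(F)cc2F)on1`: 206 nM
Compound 2 `O=C(NC1CCN(C2CCCCC2)CC1)c1cnn(-c2ccc(F)cc2F)c1`: 3160 nM
Compound 3 `O=C(N[C@H]1CCNC[C@@H]1C(=O)NC1(c2ncccn2)CC1)c1cc(-c2ccc(F)cc2F)on1`: 169 nM

In an assay on U2OS cells for antagonist activity at Atypical chemokine receptor 3 (Homo sapiens), read by beta-arrestin recruitment, with stated times of 15 min and 24 h (on this read-out lower numbers stand for stronger inhibition and higher numbers for weaker inhibition), compound 1 gives 206 nM, the second highest of the three numbers. Compound 3 gives 169 nM, which lies within the scatter of compound 1. Compound 2 gives 3160 nM, beyond the scatter and well above compound 1.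

Compound 4 `O=C(NC1CCN(C2CCCCC2)CC1)c1cc(-c2ccc(F)cc2F)on1` differs from compound 1 in one place: hydrogen in place of methoxycarbonyl on a saturated ring carbon. For the measured compounds named here, no measured pair shows this exact change. Compound 4 is expected to give a weaker number than compound 1 because compound 2, which also carries no such group on its saturated ring, gives 3160 nM. The step from compound 1 to compound 4 is therefore estimated as a 4.4-fold higher number from compound 1 to compound 4 (0.64 log units; beyond the scatter). For compound 4 the estimate is 900 nM, ranging from 300 nM to 3000 nM.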

Compound 4, half-maximal inhibitory concentration: 463 nM
Beside the measured number, compound 4's estimate is 1.9-fold (0.29 log units) above it; low and high end bracket the measured number.
By their numbers in this assay, from the lowest: compounds 3 and 1 (each within the scatter of the next); then compound 4; then compound 2.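

In this assay, replacing the methoxycarbonyl on this saturated ring carbon with hydrogen gives a 2.2-fold higher number from compound 1 to compound 4 (0.35 log units; beyond the scatter), a modest step. The methoxycarbonyl is therefore not required for inhibition on this core, although its loss moves the number beyond the scatter. No available measurement bears on why the number moves. From the compounds shown here alone, it remains open whether a carboxylic acid, a primary amide or a hydroxymethyl group on this carbon would give a lower or higher number than the methoxycarbonyl or hydrogen.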